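Phenethyl in Place of 3-Fluorophenyl on a Sulfur

This account rests on a few compounds, and the source may have more. Where it says the series, first, only, none or still open, it means among the compounds named here.

Compound 1 `Nc1ccccc1NC(=O)c1ccc(CSc2ccc(C(F)(F)F)cn2)cc1` in a functional assay on HCT-116 cells (Homo sapiens) for inhibition, read by CCK-8 assay, with a stated time of 72 h, tested at 2 uM; a lower number here means less inhibition of growth, a higher number more inhibition of growth at the concentration tested: 1.2%
Compound 2 `Nc1ccccc1NC(=O)c1ccc(CSc2cccc(F)c2)cc1` in this assay: 5.5%
Compound 3 `Nc1ccccc1NC(=O)/C=C/c1ccc(CSc2cccc3ccccc23)cc1` in this assay: 11%

Compound 2 gives the second highest of these three numbers in this assay. Its nearest neighbour is compound 1, and the gap to compound 3, the furthest, also lies within the scatter, so no ordering among the three can be read from these values; all three sit at low inhibition.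

Compound 4 `Nc1ccccc1NC(=O)c1ccc(CSCCc2ccccc2)cc1` has not yet been measured. It differs from compound 2 in one place: phenethyl in place of 3-fluorophenyl on a sulfur. Among the compounds with values here, no measured pair shows the effect of this kind of change, so the expectation rests on the low, closely grouped values of compounds 1 to 3. The step of a number 0.5 percentage points higher from compound 2 to compound 4 (within the scatter) is expected to be none beyond the scatter. Compound 4 is therefore estimated at 6%, with a range from 0% to 18%.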

Compound 4, percent growth inhibition at one concentration: 30.5%
Compound 4: middle estimate off by 24.5 percentage points, on the low side; measured number above the stated range.
By their numbers in this assay, from the lowest: compounds 1, 2 and 3 (each within the scatter of the next); then compound 4.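

Phenethyl in place of 3-fluorophenyl on a sulfur brings a number 25 percentage points higher from compound 2 to compound 4 (beyond the scatter) in this assay and is the only measured step here that clears the scatter, so the group on this sulfur can change the result. Both groups hold one six-membered aromatic ring of carbon only and no hydrogen-bond donors or acceptors, so these counts do not separate them. Nothing measured here explains the rise.

The change swaps the directly attached ring for a chain-linked one and also removes the fluorine, so these two differences cannot be told apart. A benzyl group, a longer phenylalkyl chain or a fluorinated phenethyl group on the same sulfur would help to separate them.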